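The source may report more compounds than this note shows. Statements on the series, on what has been measured and on what is new or still open speak of the compounds shown alone.

Compound 1 `Cc1ccc(S(=O)(=O)NCc2ccc(CNC(=O)c3ccccc3)cc2)cc1` is the parent of this small set. In an assay on MDA-MB-231 cells for binding affinity to C-X-C chemokine receptor type 4 (Homo sapiens), read by immunofluorescence and microscopy, with stated times of 10 min and 30 min (a higher number here means that more compound is needed for the effect, a lower number that less compound is needed), compound 1 gives > 1000 nM, which is a limit of the assay rather than a measured number (the limit of > 1000 nM in this assay, at which 1 of the 3 values shown sits). The two measured relatives alter a different part of the molecule: compound 2 `Cc1ccc(S(=O)(=O)NCc2ccc(CNC(=O)c3ccc(Cl)cc3)cc2)cc1` gives 10 nM, and compound 3 `Cc1ccc(S(=O)(=O)NCc2ccc(CNC(=O)c3cccc(F)c3)cc2)cc1` gives 1 nM. The steps of an at least 100-fold lower number from compound 1 to compound 2 (2.00 log units; beyond the scatter) and an at least 1000-fold lower number from compound 1 to compound 3 (3.00 log units; beyond the scatter) are large, while a 10-fold lower number from compound 2 to compound 3 (1.00 log units; beyond the scatter) is modest. Compound 4 `O=C(NCc1ccc(CNS(=O)(=O)c2ccccc2)cc1)c1ccccc1` differs from compound 1 in another place: hydrogen in place of methyl on an aromatic carbon. For the measured compounds named here, none of the measured steps touches the 4-methylphenyl group, so they give no direct guide here. Compound 1 stands at a limit, and compound 4 is therefore expected to stay near that limit, an expected step that the limit leaves unreadable from compound 1 to compound 4. The estimate for compound 4 is 3000 nM, with a range from 700 nM to 20000 nM.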

Compound 4, effective concentration (reported as EC, without a stated level of effect): 1 nM
Estimate against measurement, compound 4: 3000-fold (3.48 log units) above, and the stated range ends above it.
By their numbers in this assay, from the lowest: compounds 3 and 4 (each within the scatter of the next); then compound 2. At a limit, above all of these: compound 1.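

In this assay, for the compounds shown here, the change from 4-methylphenyl to phenyl gives an at least 1000-fold lower number from compound 1 to compound 4 (3.00 log units; beyond the scatter), so this end of the molecule, which the earlier steps left untouched, also responds strongly. Removing one methyl is enough here, and the phenyl on the carbonyl carbon stays free of chloro or fluoro. Compound 1 remains a limit, so the step gives only a bound: the limit of > 1000 nM in this assay, at which 1 of the 4 values shown sits.

The compounds shown leave open how a methoxy, an ethyl or a chloro group would behave at this place. They also leave open whether the chloro or fluoro changes on the other ring would still matter with phenyl here.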